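The source may report more compounds than this note shows. Statements on the series, on what has been measured and on what is new or still open speak of the compounds shown alone.

Three amide variants on the shared core have been measured in a functional assay on PC-3 cells (Homo sapiens) for antiproliferative activity, read by MTT assay, with a stated time of 24 h; on this read-out lower numbers stand for stronger inhibition and higher numbers for weaker inhibition. Compound 1 `CCn1c(C(=O)NCCN)ccc1C(CC)(CC)c1ccc(OCS(=O)(=O)c2ccccc2)c(C)c1` gives 6890 nM. Compound 2 `CCn1c(C(=O)N[C@H](C)CO)ccc1C(CC)(CC)c1ccc(OCS(=O)(=O)c2ccccc2)c(C)c1` gives 7790 nM, and compound 3 `CCn1c(C(=O)N[C@H](CO)C(C)C)ccc1C(CC)(CC)c1ccc(OCS(=O)(=O)c2ccccc2)c(C)c1` gives 7300 nM. Within this set compound 2 holds the highest number, yet its nearest neighbour compound 3 differs by only a 1.1-fold lower number from compound 2 to compound 3 (0.03 log units; within the scatter), and its furthest neighbour compound 1 by a 1.1-fold higher number from compound 1 to compound 2 (0.05 log units; within the scatter), so the three stand together within the scatter and no order among them can be claimed.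

The next step goes from compound 2 to compound 4 `CCn1c(C(=O)NCCC(=O)O)ccc1C(CC)(CC)c1ccc(OCS(=O)(=O)c2ccccc2)c(C)c1`. The change is 2-carboxyethyl in place of 1-(hydroxymethyl)ethyl on an amide-type nitrogen. The measured steps that bear on it are those at the same amide-type nitrogen: a 1.1-fold higher number from compound 1 to compound 2 (0.05 log units; within the scatter), a 1.1-fold higher number from compound 1 to compound 3 (0.03 log units; within the scatter) and a 1.1-fold lower number from compound 2 to compound 3 (0.03 log units; within the scatter). None of them moved the number beyond the scatter, whether the substituent carried an amino group, a hydroxymethyl group or a branched chain. Among the compounds with values here, no step with a carboxylic acid on this nitrogen has been measured, so the expectation rests on the indifference seen so far.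

For compound 4 in this assay a step of a 1.0-fold lower number from compound 2 to compound 4 (0.02 log units; within the scatter) is therefore expected, that is, none beyond the scatter. The estimated value for compound 4 is 7500 nM, expected to lie between 3500 nM and 16000 nM.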

Compound 4, half-maximal inhibitory concentration: 14400 nM
Estimate against measurement, compound 4: 1.9-fold (0.28 log units) below; the range from low to high includes it.
By their numbers in this assay, from the lowest: compounds 1, 3, 2 and 4 (each within the scatter of the next, the first and the last beyond it).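

Within the data shown here, at the amide-type nitrogen, the only step in this assay that passes the scatter is the modest one of carboxy in place of amino on the saturated chain (a 2.1-fold higher number from compound 1 to compound 4 (0.32 log units; beyond the scatter)). Among these compounds, measured against the two substituents carrying a hydroxymethyl group, 2-carboxyethyl stays within the scatter (a 1.8-fold higher number from compound 2 to compound 4 (0.27 log units; within the scatter); a 2.0-fold higher number from compound 3 to compound 4 (0.30 log units; within the scatter)), so this position is not wholly indifferent, but only the pair with the amino and carboxy chain ends separates, and narrowly. No measured property in hand accounts for this step.

As far as these compounds go, it remains open whether the step belongs to the free carboxylic acid itself or to any group at the end of that chain, a question that a methyl ester or a primary amide on the same chain would address, as would a longer chain carrying the acid. Also open, from the compounds shown here alone, is whether any substituent on this nitrogen, such as a tertiary amine or a phenyl ring, would take the number well clear of the narrow band that these four compounds occupy.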